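The source may report more compounds than this note shows. Statements on the series, on what has been measured and on what is new or still open speak of the compounds shown alone.

Measured compounds in a functional assay on SGC-7901 cells (Homo sapiens) for antiproliferative activity, read by MTT assay, with a stated time of 24 h; a lower number here means a stronger inhibitor, a higher number a weaker inhibitor:
compound 1 `O=C(NNC(=O)c1ccccc1F)c1ccc(NS(=O)(=O)c2cnc(O)nc2O)cc1` gives a limit of the assay, > 20000 nM.
compound 2 `O=C(NNC(=O)c1ccc(NS(=O)(=O)c2cnc(O)nc2O)cc1)c1ccc(F)cc1` gives a limit of the assay, > 20000 nM.
compound 3 `O=C(NNC(=O)c1ccccc1NS(=O)(=O)c1cnc(O)nc1O)c1ccccc1F` gives a limit of the assay, > 20000 nM.

None of the three values is a number, and all of them stand at the limit of > 20000 nM in this assay, at which 3 of the 3 values shown sit. From compound 1 to compound 2 the change is 4-fluorophenyl in place of 2-fluorophenyl on a carbonyl carbon. The step this makes, a step that the two limits leave unreadable from compound 1 to compound 2, is not readable, as both ends are limits. The difference between the core of compound 1 and the core of compound 3 is not broken down here.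

Compound 4 `O=C(NNC(=O)c1ccccc1NS(=O)(=O)c1cnc(O)nc1O)c1ccc(F)cc1` is still to be measured in this assay. It differs from compound 3 by 4-fluorophenyl in place of 2-fluorophenyl on a carbonyl carbon, the same kind of change as from compound 1 to compound 2, with the place described in the same words in both cases. The earlier instance of this change gave no readable step, and every measured value is a limit, so compound 4 is expected to give a limit as well.

The estimate for compound 4 in this assay is 30000 nM, expected to lie between 20000 nM and 80000 nM. The expected step is a step that the limit leaves unreadable from compound 3 to compound 4, which rests on all measured values sitting at the limit of > 20000 nM in this assay, at which 3 of the 3 values shown sit.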

Compound 4, half-maximal inhibitory concentration: > 20000 nM
Compound 4 gave a limit, no number; the forecaster's own chance of this, stated with the estimate: 90%; the middle value is on the limit's open side.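

Compound 3 and compound 4 both give only limits in this assay, so the step between them, like the earlier one from compound 1 to compound 2, cannot be read: the limit of > 20000 nM in this assay, at which 4 of the 4 values shown sit.

The compounds shown leave open how far past that limit any of the four lies, and whether 2-fluorophenyl and 4-fluorophenyl differ at all in this assay.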